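The compounds below may be only part of what the source reports. "The series", "measured", "known", "first", "only" and "open" are said of these compounds alone.

Two members of this series carry measured numbers in an assay on isolated protein for displacement of a labelled ligand from 5-hydroxytryptamine receptor 6 (Homo sapiens); a lower number here means a stronger inhibitor, a higher number a weaker inhibitor. Compound 1 `O=S(=O)(c1cccc(F)c1)c1ccc2c(c1)CCC[C@H]2CN1CCCS1(=O)=O` gives 31.6 nM there. Compound 2 `CNCC(=O)NC[C@@H]1CCCc2cc(S(=O)(=O)c3cccc(F)c3)ccc21` gives 0.159 nM in this assay. For the measured compounds named here, the single step joining them, a 200-fold lower number from compound 1 to compound 2 (2.30 log units; beyond the scatter), leaves compound 2 with the lowest of the two numbers, with compound 1 as its only neighbour. Compound 3 `CS(=O)(=O)NC[C@@H]1CCCc2cc(S(=O)(=O)c3cccc(F)c3)ccc21` is the next member to be measured in this assay: methylsulfonyl in place of ((methylamino)methyl)carbonyl on an amine nitrogen. Going by the values given here, the only measured step that bears on this change is a 200-fold lower number from compound 1 to compound 2 (2.30 log units; beyond the scatter), in which a sulfonyl-bearing ring on the saturated chain carbon gave way to the ((methylamino)methyl)carbonyl amine; compound 3 brings a sulfonyl back to that part of the molecule, though without the ring of compound 1. Compound 3 is therefore expected to show a higher number, a step of roughly a 31-fold higher number from compound 2 to compound 3 (1.50 log units; beyond the scatter). The estimate for compound 3 in this assay is 5 nM, with a range from 1 nM to 30 nM.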

Compound 3, inhibition constant: 0.2 nM
Beside the measured number, compound 3's estimate is 25-fold (1.40 log units) above it, and the stated range ends above it.
By their numbers in this assay, from the lowest: compounds 2 and 3 (each within the scatter of the next); then compound 1.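

On the amine nitrogen, the step of a 1.3-fold higher number from compound 2 to compound 3 (0.10 log units; within the scatter) in this assay does not separate methylsulfonyl from ((methylamino)methyl)carbonyl, so a number this low does not depend on the hydrogen-bond donor or the nitrogen of the group that leaves. A sulfonyl in this part of the molecule is also compatible with a low number: with a 160-fold lower number from compound 1 to compound 3 (2.20 log units; beyond the scatter) still large, the sulfonyl alone does not set compound 1 apart, and the five-membered ring of compound 1 is the remaining difference in this step. No measurement at hand accounts for either step.

The compounds shown leave open whether a longer chain on the sulfonyl, such as ethylsulfonyl or phenylsulfonyl, keeps the number of compound 3. Also open, from the compounds shown here alone, is how a plain acetyl or a bare primary amine at that nitrogen would read.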